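Cyano to 4-chlorophenyl: working notes on compound 3

The source may report more compounds than this note shows. Statements on the series, on what has been measured and on what is new or still open speak of the compounds shown alone.

Measured so far in a functional assay on SEM cells (Homo sapiens) for cytotoxicity, with a stated time of 72 h (a lower number here means that less compound is needed, a higher number that more compound is needed for the effect), all as limits:
compound 1 `C=C[C@@](C)(/C=C/c1ccc(OS(=O)(=O)c2ccc(C)cc2)cc1)CCC=C(C)C` gives > 43400 nM
compound 2 `C=C[C@@](C)(/C=C/c1ccc(O)cc1)CC/C=C/C#N` gives > 36600 nM
compound 3 `C=C[C@@](C)(/C=C/c1ccc(O)c(/C=C/C#N)c1)CCC=C(C)C` gives > 36600 nM

Compound 3 gives > 36600 nM as a limit and not a number. Compound 2 also gives > 36600 nM as a limit. Compound 1 gives > 43400 nM as a limit as well. The series therefore holds no measured number, and compound 3 cannot be ranked against compound 1 or compound 2.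

The next compound is compound 4 `C=C[C@@](C)(/C=C/c1ccc(O)c(/C=C/c2ccc(Cl)cc2)c1)CCC=C(C)C`. The change is 4-chlorophenyl in place of cyano on a double-bonded chain carbon bound to a double-bonded chain carbon and, cut one bond further out, it reads 2-cyanoethenyl to 2-(4-chlorophenyl)ethenyl. Among the compounds with values here, the series offers no measured step to size such a change. The expected step of an at least 1.8-fold lower number from compound 3 to compound 4 (0.26 log units; that floor lies within the scatter) is modest and points towards less compound needed in this assay for the effect. A report of only a limit again remains about as likely as a number. For compound 4 the expected value is 20000 nM (estimated range 6000 nM to 36000 nM).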

Compound 4, half-maximal effective concentration: > 36600 nM
Compound 4: a limit, no number (the forecaster's own chance of this, stated with the estimate: 55%); middle value at least 1.8-fold (0.26 log units) from the limit.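

No step from compound 3 to compound 4 can be read in this assay, because compound 4 gives a limit, as compound 3 does: the limit of > 36600 nM in this assay, at which 3 of the 4 values shown sit.

The compounds shown leave open whether 4-chlorophenyl in place of cyano changes the half-maximal effective concentration at all, and how the four compounds rank.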